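The source may report more compounds than this note shows. Statements on the series, on what has been measured and on what is new or still open speak of the compounds shown alone.

Measured so far in a functional assay on the whole organism for inhibition, with Brassica rapa subsp. chinensis as the target, with a stated time of 3 days, tested at 100 ppm; on this read-out lower numbers stand for less inhibition of growth and higher numbers for more inhibition of growth at the one concentration tested:
compound 1 `CCCCCCNC(=O)/C=C/c1ccccc1` gives 55%
compound 2 `CCCCCCCCCCNC(=O)/C=C/c1ccccc1` gives 10%
compound 3 `COC(=O)/C=C/c1ccc(C(C)C)cc1` gives 38%

Among the compounds with values here, the only step between measured compounds that differ in one place is a number 45 percentage points lower from compound 1 to compound 2 (beyond the scatter), the change being (butyl in place of hydrogen on a saturated chain carbon, six bonds along the chain from an amide-type nitrogen). Compound 3 stands second highest of the three numbers; its nearest neighbour is compound 1 and its furthest is compound 2, both gaps lying beyond the scatter. The difference between the core of compound 3 and the core of compound 1 is not broken down here.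

Compound 4 `CCCCCOC(=O)/C=C/c1ccc(C(C)C)cc1` is still to be measured in this assay. It differs from compound 3 by butyl in place of hydrogen on a saturated chain carbon bound to an oxygen next to a carbonyl group. This is the same kind of change as that from compound 1 to compound 2, not the same change: there the place is on a saturated chain carbon six bonds along the chain from an amide-type nitrogen, here it is on a saturated chain carbon bound to an oxygen next to a carbonyl group. On that single precedent, compound 4 is expected to move from compound 3 by a number 23 percentage points lower from compound 3 to compound 4 (beyond the scatter), in the same direction as a number 45 percentage points lower from compound 1 to compound 2 (beyond the scatter) but smaller, because compound 3 starts from 38% and the read-out cannot fall below zero. Compound 4 is thus estimated at 15%, with the expected range from 0% to 40%.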

Compound 4, percent growth inhibition at one concentration: 29%
Compound 4: middle estimate off by 14 percentage points, on the low side; the range from low to high includes it.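

In this assay the new step reads a number 9 percentage points lower from compound 3 to compound 4 (within the scatter), so on the core of compound 3 the butyl group in place of hydrogen gives no change that can be told from the usual spread of repeats. Set beside the earlier step, the same change does not carry over in size from one core to the other: the same change on two cores in this assay, a number 45 percentage points lower (beyond the scatter) from compound 1 to compound 2 and a number 9 percentage points lower (within the scatter) from compound 3 to compound 4, 36 percentage points apart, beyond the scatter of two such steps

Which difference between the two cores sets this gap is not shown, and with only two pairs, each measured at one concentration, no rule follows for a third core, nor does it follow that the change is always without effect on the core of compound 3.

Still open, on these data alone, is how a longer chain on the oxygen of the core of compound 3 would read, and whether a larger step would then appear. Also open, as far as these compounds go, is how a carboxylic acid or an amine would read at the place that carries the chain.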